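Swapping chloro for fluoro on the benzyl group of compound 1

The compounds below may be only part of what the source reports. "The series", "measured", "known", "first", "only" and "open" are said of these compounds alone.

Measured so far:
compound 1, `NC(N)=NC(=O)c1nc(Cl)c(NCc2ccccc2Cl)nc1N`: 31%
compound 2, `NC(N)=NC(=O)c1nc(Cl)c(N2CCCC2)nc1N`: 12%

Of the compounds shown here, two sharing one core have been tested in an assay for inhibition of acid-sensing ion channel 3 (Homo sapiens), read by patch clamp, tested at 1 uM; a lower number here means less inhibition, a higher number more inhibition at the concentration tested (going by the name of the read-out). Compound 1, `NC(N)=NC(=O)c1nc(Cl)c(NCc2ccccc2Cl)nc1N`, gives 31%, the higher of the two numbers. Compound 2, `NC(N)=NC(=O)c1nc(Cl)c(N2CCCC2)nc1N`, gives 12% in this assay, a gap from compound 1 that lies beyond the usual scatter. Among the measured compounds shown here, no pair of measured compounds differs in a single place, so no step between them is recorded, and the two values are noted only as they stand.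

The next compound is compound 3, `NC(N)=NC(=O)c1nc(Cl)c(NCc2ccccc2F)nc1N`. Its difference from compound 1 is small: fluoro in place of chloro on an aromatic carbon. The rest of the molecule is unchanged.

For the measured compounds named here, with only two measured compounds and no recorded step of this kind, the account expects the move from compound 1 to compound 3 to be modest in this assay, at most a slight loss that may not exceed the scatter, the expected step being a number 6 percentage points lower from compound 1 to compound 3 (within the scatter). Compound 3 is therefore estimated at 25%, with a range from 10% to 40%, against which the measured number can be set.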

Compound 3, a percentage reported as inhibition, at one concentration (the size of the read-out at that concentration, not a potency): 26%
The estimate for compound 3 lay 1 percentage points below the measured number; the measured number falls inside the stated range.
By their numbers in this assay, from the lowest: compound 2; then compounds 3 and 1 (each within the scatter of the next).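

Among the compounds shown here, the exchange of 2-chlorophenyl for 2-fluorophenyl gives the first single-place comparison, and in this assay it amounts to a number 5 percentage points lower from compound 1 to compound 3 (within the scatter). At this place, on an aromatic carbon ortho to a large group, the read-out therefore does not separate chloro from fluoro, and compound 3 keeps a reading that cannot be told apart from that of compound 1. No measurement at hand bears on why these two compounds read alike.

From the compounds shown here alone, the step covers only these two halogens at this one place, so it remains open whether a methyl, a methoxy, a trifluoromethyl or a plain hydrogen at the same carbon would also stay within the scatter or would move the reading beyond it. Also open, going by these compounds, is whether fluoro would behave the same way elsewhere on the six-membered aromatic ring, and, since this assay reports inhibition at one concentration only, whether compound 1 and compound 3 would still read alike across a range of concentrations.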